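Amide swap on compound 2 in a weak series

The compounds below may be only part of what the source reports. "The series", "measured", "known", "first", "only" and "open" are said of these compounds alone.

Two compounds anchor the series in a functional assay on MIA PaCa-2 cells (Homo sapiens) for inhibition, read by MTT assay; on this read-out lower numbers stand for stronger inhibition and higher numbers for weaker inhibition. Compound 1 (`O=C(Nc1ccccc1)c1cc2cnc(N3CCN(c4ccc(Cl)cc4)CC3)nc2n1C1CCCC1`) reads > 200000 nM, which is a limit of the assay and not a number. Within the data shown here, compound 2 (`O=C(c1cc2cnc(Nc3ccc(N4CCNCC4)cn3)nc2n1C1CCCC1)N1CCCCC1`) gives 39600 nM, the only true number so far, so its standing rests on this single value.

Compound 3 (`COc1cccc(NC(=O)c2cc3cnc(Nc4ccc(N5CCNCC5)cn4)nc3n2C2CCCC2)c1`) changes compound 2 at the amide: (3-methoxyphenyl)amino in place of piperidin-1-yl on a carbonyl carbon. In words, (3-methoxyphenyl)amino stands in place of piperidin-1-yl on a carbonyl carbon.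

Among the measured compounds shown here, no measured step covers this change, so the only anchor is compound 2 at 39600 nM. The estimated 1.1-fold lower number from compound 2 to compound 3 (0.05 log units; within the scatter) stays within the usual scatter, and no shift in either direction is expected. Compound 3 is expected at 35000 nM, with an estimated range of 10000 nM to 120000 nM.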

Compound 3, half-maximal inhibitory concentration: 2650 nM
Compound 3: middle estimate off by 13-fold (1.12 log units), on the high side; measured number outside the range, below it.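

In this assay the substituent on the carbonyl carbon proves to matter, which compound 2 alone could not show: a 15-fold lower number from compound 2 to compound 3 (1.17 log units; beyond the scatter). Among these compounds, this is the only readable step so far, and it rests on a single pair. The change replaces a six-membered non-aromatic ring with no hydrogen-bond donors by a six-membered aromatic ring of carbon only, with 1 hydrogen-bond donor and 1 hydrogen-bond acceptor, and this one step cannot tell which of these differences carries the shift.

The compounds shown do not separate the methoxy group from the phenyl ring, and they say nothing about an open-chain amine such as diethylamino on the same carbonyl carbon. Compound 1 differs from compound 3 in more than one place and gives only a limit, not a number: the limit of > 200000 nM in this assay, at which 1 of the 3 values shown sits.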